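Chlorophenyl amides of the shared core in the writhing test

A few compounds are considered here, and "the series" means these few. Any claim that something is new, unique, unknown or untested is made for them only; others in the source may bear on it.

Among the compounds with values here, compound 1 `CC(=O)Oc1ccc(-c2ccc(F)cc2F)cc1C(=O)O` and compound 2 `CC(=O)Oc1ccc(-c2ccc(F)cc2F)cc1C(=O)Nc1ccccc1Cl` are the two measured members. In a functional assay on the whole organism (strain Kunming) for inhibition, with Mus musculus as the target, in the writhing test, at a dose of 40 mg/kg by the oral route (a higher number here means more inhibition at the dose given (going by the name of the read-out), a lower number less inhibition), compound 1 gives 0%, while compound 2 gives 11.7%; this difference, a number 11.7 percentage points higher from compound 1 to compound 2 (beyond the scatter), came with (2-chlorophenyl)amino in place of hydroxy on a carbonyl carbon. Compound 2 thus stands highest of the two numbers. Compound 3 `CC(=O)Oc1ccc(-c2ccc(F)cc2F)cc1C(=O)Nc1ccc(Cl)cc1` differs from compound 2 by 4-chlorophenyl in place of 2-chlorophenyl on an amide-type nitrogen. Within the data shown here, no measured step covers a change of this kind; the one known step concerns the amide itself. A step of no size beyond the scatter is therefore expected, a number 0.3 percentage points higher from compound 2 to compound 3 (within the scatter). Compound 3 is estimated at 12%, between 0% and 30%.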

Compound 3, a percentage reported as inhibition, in the whole organism at one dose (the size of the read-out at that dose, not a potency): 29.9%
Beside the measured number, compound 3's estimate is 17.9 percentage points below it; low and high end bracket the measured number.
By their numbers in this assay, from the lowest: compound 1; then compound 2; then compound 3.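

In this assay, the place of the chlorine on the phenyl group carried by the amide-type nitrogen matters: 4-chlorophenyl in place of 2-chlorophenyl, with the same atoms joined differently, gives a step beyond the scatter (a number 18.2 percentage points higher from compound 2 to compound 3 (beyond the scatter)). The gain over the hydroxy of compound 1 therefore depends on which chlorophenyl amide is present, and it is larger for the 4-chlorophenyl amide (a number 29.9 percentage points higher from compound 1 to compound 3 (beyond the scatter)). Nothing available on the series accounts for this difference.

Still open, as far as these compounds go, is how an unsubstituted phenyl, 4-fluorophenyl or 4-methoxyphenyl on this nitrogen would compare with compound 3.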